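Swapping a Five-Membered Ring on Two Related Cores

The source may report more compounds than this note shows. Statements on the series, on what has been measured and on what is new or still open speak of the compounds shown alone.

Measured so far in a functional assay on U-87MG ATCC cells for inhibition, with U-87 MG (Homo sapiens) as the target, read by MTT assay, with a stated time of 72 h; on this read-out higher numbers stand for weaker inhibition and lower numbers for stronger inhibition:
Compound 1 `Cc1noc(C)c1-c1cnc(N)c(Oc2ccc(C(=O)Nc3ccc(Cl)cn3)cc2)n1` gives 45600 nM.
Compound 2 `Cn1cc(-c2cnc(N)c(Oc3ccc(C(=O)Nc4ccc(Cl)cn4)cc3)n2)cn1` gives 22200 nM.
Compound 3 `Cc1noc(C)c1-c1cnc(N)c(NCc2ccc(C(=O)Nc3ccc(Cl)cc3)cc2)n1` reaches only a limit of this assay, > 100000 nM.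

Compound 2 differs from compound 1 by 1-methyl-1H-pyrazol-4-yl in place of 3,5-dimethyl-1,2-oxazol-4-yl on an aromatic carbon, and this change made a step of a 2.1-fold lower number from compound 1 to compound 2 (0.31 log units; beyond the scatter). The value of compound 3 is a limit, not a number; it is the limit of > 100000 nM in this assay, at which 1 of the 3 values shown sits. How the core of compound 3 differs from the core of compound 1 is not broken down here. Compound 4 `Cn1cc(-c2cnc(N)c(NCc3ccc(C(=O)Nc4ccc(Cl)cc4)cc3)n2)cn1` is not yet measured and carries the same change as before, (1-methyl-1H-pyrazol-4-yl in place of 3,5-dimethyl-1,2-oxazol-4-yl on an aromatic carbon), at the same place. Beside the earlier step, a step of a number no higher from compound 3 to compound 4 (the limit leaves the size open) is expected in this assay, an expectation resting on a 2.1-fold lower number from compound 1 to compound 2 (0.31 log units; beyond the scatter). Compound 4 is therefore estimated at 100000 nM, between 40000 nM and 300000 nM, and a limit may well be reported again.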

Compound 4, half-maximal inhibitory concentration: > 100000 nM
Compound 4 ended at the assay's limit (the forecaster's own chance of this, stated with the estimate: 65%); the middle value lies on the limit itself.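

Compound 3 and compound 4 both end at a limit rather than a number, so the step between them cannot be read: the limit of > 100000 nM in this assay, at which 2 of the 4 values shown sit.

Going by these compounds, whether 1-methyl-1H-pyrazol-4-yl changes the number on this core, as it did from compound 1 to compound 2, stays open.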